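Phenyl for ethyl on the pyrazole nitrogen: a second look

A few compounds are considered here, and "the series" means these few. Any claim that something is new, unique, unknown or untested is made for them only; others in the source may bear on it.

Measured compounds:
- compound 1, `CCOC(=O)c1cc(-c2ccc(OC(=O)NC3CCCCC3)cc2)n(CC)n1`: 214 nM
- compound 2, `CCOC(=O)c1cc(-c2ccc(OC(=O)NC3CCCCC3)cc2)n(-c2ccccc2)n1`: 268 nM
- compound 3, `CCOC(=O)c1cc(-c2cccc(OC(=O)NC3CCCCC3)c2)nn1CC`: 507 nM

These three carbamates were tested in an assay on isolated protein for inhibition of Fatty-acid amide hydrolase 1 (Homo sapiens), read by fluorescence, with a stated time of 30 min; a higher number here means a weaker inhibitor, a lower number a stronger inhibitor. Compound 1 gives 214 nM and compound 2 gives 268 nM, so that the change between them, (phenyl in place of ethyl on an aromatic nitrogen), made a step of a 1.3-fold higher number from compound 1 to compound 2 (0.10 log units; within the scatter). Compound 3 gives 507 nM; it holds the same atoms as compound 1, joined differently, and the difference between the two cores is not broken down here.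

Compound 4, `CCOC(=O)c1cc(-c2cccc(OC(=O)NC3CCCCC3)c2)nn1-c1ccccc1`, has not yet been measured. It arises from compound 3 by phenyl in place of ethyl on an aromatic nitrogen. Within the data shown here, this is the same kind of change as the one from compound 1 to compound 2, though not the same: in compound 2 the phenyl sits next to the ring atom that bears a large group and two ring bonds from the ring atom that bears an ethoxycarbonyl group, whereas in compound 4 it sits next to the ring atom that bears an ethoxycarbonyl group and two ring bonds from the ring atom that bears a large group. The change occurs twice among the compounds shown.

Because the earlier step was a 1.3-fold higher number from compound 1 to compound 2 (0.10 log units; within the scatter), a step of similar size is expected in this assay from compound 3 to compound 4, namely a 1.3-fold higher number from compound 3 to compound 4 (0.11 log units; within the scatter). Among the measured compounds shown here, compound 4 is therefore estimated at 650 nM, between 300 nM and 1400 nM, with the single earlier example leaving the estimate wide.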

Compound 4, half-maximal inhibitory concentration: 539 nM
Beside the measured number, compound 4's estimate is 1.2-fold (0.08 log units) above it, and the stated range covers the measured number.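

In this assay, phenyl in place of ethyl on an aromatic nitrogen gives a 1.1-fold higher number from compound 3 to compound 4 (0.03 log units; within the scatter), so on this core the swap leaves the reading inside the normal spread of repeated measurements. Among these compounds, this does not show that the nitrogen substituent is unimportant in general: there are only two pairs, ethyl and phenyl are the only groups compared, and neither step is large enough to reveal a trend or to say why the two groups read alike. What the pairs do show is that the change behaves the same way on both cores, with no difference between them that these measurements can separate: the same change on two cores in this assay, a 1.3-fold higher number (0.10 log units; within the scatter) from compound 1 to compound 2 and a 1.1-fold higher number (0.03 log units; within the scatter) from compound 3 to compound 4, 1.2-fold (0.07 log units) apart, within the scatter of two such steps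

The compounds shown leave open whether other groups on that nitrogen, such as a methyl, a benzyl or a longer chain, would also read like ethyl and phenyl, and whether the match between the two cores would survive with any of them. They also leave open what happens when the ethoxycarbonyl group gives way to a carboxylic acid or an amide, since it stays the same in all four compounds, and so the swap has been followed only with that group in place.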